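A few compounds are considered here, and "the series" means these few. Any claim that something is new, unique, unknown or untested is made for them only; others in the source may bear on it.

Compound 1 `Nc1ncc(-c2cnn(C3CCNCC3)c2)cc1-c1nc2ccc(Nc3cc(C(F)(F)F)cc(C(F)(F)F)c3)cc2o1` gives 4200 nM in an assay on isolated protein for inhibition of G protein-coupled receptor kinase 5 (Homo sapiens), read by TR-FRET, with stated times of 10 min and 1 h; on this read-out lower numbers stand for stronger inhibition and higher numbers for weaker inhibition.
Compound 2 `Nc1ncc(-c2cnn(C3CCNCC3)c2)cc1-c1nc2ccc(Oc3ccccc3)cc2o1` gives 4000 nM in this assay.
Compound 3 `Nc1ncc(-c2cnn(C3CCNCC3)c2)cc1-c1nc2ccc(Oc3cc(Cl)ccn3)cc2o1` gives 5700 nM in this assay.

Compound 3 stands at the highest number of the three, but its gaps to compound 1 and to compound 2 are both within the scatter, so the three measured compounds cannot be ranked against one another. Among the compounds with values here, the only single-point step among them, a 1.4-fold higher number from compound 2 to compound 3 (0.15 log units; within the scatter), likewise stays within the scatter.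

Compound 4 `COc1ccc(-c2ccc3nc(-c4cc(-c5cnn(C6CCNCC6)c5)cnc4N)oc3c2)cc1` differs from compound 3 at one place: 4-methoxyphenyl in place of (4-chloropyridin-2-yl)oxy on an aromatic carbon. Within the data shown here, no measured step bears directly on this change, since the step from compound 2 to compound 3 exchanges one ring for another while keeping the oxygen link, whereas here the oxygen link itself leaves and a ring bound directly to the core enters. Among the measured compounds shown here, the measured steps in this assay say only that changes at this part of the core have so far stayed within the scatter.

On that basis compound 4 is expected to show no step beyond the scatter, a 1.3-fold lower number from compound 3 to compound 4 (0.10 log units; within the scatter), and its number in this assay is estimated at 4500 nM, within a range of 1500 nM to 13000 nM.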

Compound 4, half-maximal inhibitory concentration: 3220 nM
For compound 4 the middle estimate is 1.4-fold (0.15 log units) above the measured one; the range from low to high includes it.
By their numbers in this assay, from the lowest: compounds 4, 2, 1 and 3 (each within the scatter of the next).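

In this assay, within the data shown here, the earlier compounds all carried their ring at this position through a linking atom, so they could show only what happens when that ring or its link is exchanged. Compound 4 shows that the oxygen link itself can leave, with 4-methoxyphenyl bound directly to the aromatic carbon, and that the read-out still does not separate the compounds: replacing (4-chloropyridin-2-yl)oxy gives a 1.8-fold lower number from compound 3 to compound 4 (0.25 log units; within the scatter), and replacing phenoxy gives a 1.2-fold lower number from compound 2 to compound 4 (0.09 log units; within the scatter). Nothing presented here accounts for why these exchanges at this position, with or without the oxygen link, leave the numbers within the scatter of one another.

The compounds shown leave open whether anything placed at this position can move the number beyond the scatter, as every group here is a six-membered aromatic ring, bound directly or through a single linking atom. A primary amine, a carboxylic acid or a longer alkyl chain at the same aromatic carbon would test whether that ring is required at all, and whether this position has any real influence on the number in this assay.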